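A few compounds are considered here, and "the series" means these few. Any claim that something is new, unique, unknown or untested is made for them only; others in the source may bear on it.

The measured compounds:
compound 1, `Cc1cccc(-c2n[nH]cc2N2CCCNCC2)c1`, giving 636 nM in an assay on isolated protein for binding affinity to 5-hydroxytryptamine receptor 6 (Homo sapiens); on this read-out lower numbers stand for stronger inhibition and higher numbers for weaker inhibition
compound 2, `Cc1ccc(-c2n[nH]cc2N2CCCNCC2)cc1`, giving 1320 nM in this assay
compound 3, `Clc1ccc(-c2n[nH]cc2N2CCCNCC2)cc1`, giving 1090 nM in this assay

Compound 3 stands second highest of these three numbers. Compound 2 is its nearest neighbour, and compound 1 its furthest, and both gaps to compound 3 lie within the scatter, so the three compounds are not told apart by this read-out.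

Compound 4, `Fc1ccc(-c2n[nH]cc2N2CCCNCC2)cc1`, differs from compound 3 in one place: fluoro in place of chloro on an aromatic carbon. Among the compounds with values here, only one measured step touches the same carbon: a 1.2-fold lower number from compound 2 to compound 3 (0.08 log units; within the scatter). That exchange of a methyl for a chloro produced no movement beyond the scatter. The present exchange of chloro for fluoro at the same carbon has no measured counterpart among these compounds, and the one step that bears on it gives no ground to expect a shift in either direction beyond the scatter.

The expectation for compound 4 in this assay is therefore a step of a 1.0-fold higher number from compound 3 to compound 4 (0.00 log units; within the scatter) from compound 3. Compound 4 is estimated at 1100 nM, with a range from 500 nM to 2500 nM.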

Compound 4, inhibition constant: 2290 nM
Estimate against measurement, compound 4: 2.1-fold (0.32 log units) below; the measured number falls inside the stated range.
By their numbers in this assay, from the lowest: compounds 1, 3, 2 and 4 (each within the scatter of the next, the first and the last beyond it).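

On the aromatic carbon para to a large group, the earlier exchange of methyl for chloro had shown no movement beyond the scatter, but in this assay the exchange of chloro for fluoro does move the number (a 2.1-fold higher number from compound 3 to compound 4 (0.32 log units; beyond the scatter)), so the outcome at this carbon depends on which substituent is exchanged for which, although the step is modest and rests on a single pair. Within the data shown here, the exchange of methyl for fluoro at the same carbon stays within the scatter (a 1.7-fold higher number from compound 2 to compound 4 (0.24 log units; within the scatter)), which leaves compound 2 unseparated from either halogen compound and makes chloro and fluoro the only pair at this carbon that this assay tells apart. Nothing available here accounts for the difference between the chloro and fluoro compounds.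

The compounds shown leave open whether a larger halogen such as bromo, or a group such as methoxy, trifluoromethyl or an amine, would extend or break this small separation at the same carbon. They also leave open whether chloro or fluoro on the carbon that carries the methyl in compound 1 would behave as it does here.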